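Chain Extension on a Shared Core: Expected Inactivity

The compounds below may be only part of what the source reports. "The series", "measured", "known", "first", "only" and "open" are said of these compounds alone.

Compound 1 `CCCCc1cc2ccccc2nc1-c1cc(-c2ccccc2)no1` and compound 2 `CCCCCc1cc2ccccc2nc1-c1cc(-c2ccccc2)no1` share one core, and compound 3 `CCc1cc2ccccc2nc1-c1cc(-c2ccc(F)cc2)no1` carries a related one; how the core of compound 3 differs from that of compound 1 is not broken down here. In a functional assay on COLO 205 cells (Homo sapiens) for inhibition, read by MTT assay, with a stated time of 24 h (on this read-out lower numbers stand for stronger inhibition and higher numbers for weaker inhibition), compound 1 reaches only a limit, > 100000 nM. Compound 2 likewise gives only a limit in this assay, > 100000 nM. Compound 3 also sits at a limit, > 100000 nM. The change from compound 1 to compound 2 is methyl in place of hydrogen on a saturated chain carbon, four bonds along the chain from an aromatic carbon; because both values rest at the limit of > 100000 nM in this assay, at which 3 of the 3 values shown sit, the step that the two limits leave unreadable from compound 1 to compound 2 cannot be read. Compound 4 `CCCc1cc2ccccc2nc1-c1cc(-c2ccc(F)cc2)no1` arises from compound 3 by the same kind of change, (methyl in place of hydrogen on a saturated chain carbon, two bonds along the chain from an aromatic carbon), placed two bonds rather than four bonds along the chain from an aromatic carbon. The shown values give no direction for this change. Compound 4 is therefore expected to give 150000 nM, an expected step that the limit leaves unreadable from compound 3 to compound 4, most likely again only a limit.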

Compound 4, half-maximal inhibitory concentration: 50300 nM
The estimate for compound 4 lay 3.0-fold (0.47 log units) above the measured number, within the range that was stated.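

On the core of compound 3, methyl in place of hydrogen on a saturated chain carbon, two bonds along the chain from an aromatic carbon, gives an at least 1.9-fold lower number from compound 3 to compound 4 (0.29 log units; that floor lies within the scatter) in this assay. Compound 3 holds only a limit here, which leaves the true size of this step unknown, and its floor alone does not establish a real gain. The step from compound 1 to compound 2, on the other core and at another place on the chain, cannot be read, and no comparison between the cores is possible because most values rest at a limit: the limit of > 100000 nM in this assay, at which 3 of the 4 values shown sit.

Still open, as far as these compounds go, is whether a longer chain on the core of compound 3 would lower the number further. Also open, from the compounds shown here alone, is how an amine in place of that methyl would read.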